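Chloro in Place of Bromo in a Cytotoxicity Series

This account rests on a few compounds, and the source may have more. Where it says the series, first, only, none or still open, it means among the compounds named here.

Measured so far:
compound 1 `C=CC(=O)Nc1cc(Nc2ncc3ncn(-c4ccc(Br)cc4)c3n2)c(OC)cc1N(C)CCN(C)C`: 1460 nM
compound 2 `C=CC(=O)Nc1cc(Nc2ncc3ncn(-c4ccc(F)c(Br)c4)c3n2)c(OC)cc1N(C)CCN(C)C`: 3640 nM

In an ADME assay on HT-29 cells (Homo sapiens) for cytotoxicity, read by MTT assay, with a stated time of 72 h (on this read-out lower numbers stand for stronger inhibition and higher numbers for weaker inhibition), compound 1 gives 1460 nM, and compound 2 gives 3640 nM. Going by the values given here, compound 2 therefore holds the highest of the two numbers, and the only measured step is a 2.5-fold higher number from compound 1 to compound 2 (0.40 log units; beyond the scatter), a modest change that exchanges one halogen pattern for another on the aryl group attached to the aromatic nitrogen.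

Compound 3 `C=CC(=O)Nc1cc(Nc2ncc3ncn(-c4ccc(F)c(Cl)c4)c3n2)c(OC)cc1N(C)CCN(C)C` differs from compound 2 by chloro in place of bromo on an aromatic carbon. Among the compounds with values here, no measured step swaps a single halogen for another at one place, so the step from compound 1 to compound 2 bears on it only loosely: it shows that altering the halogens on this ring moves the number modestly at best. A change no larger than the usual scatter is expected here, namely a 1.2-fold lower number from compound 2 to compound 3 (0.08 log units; within the scatter). Compound 3 is estimated at 3000 nM, with a range from 1400 nM to 7000 nM.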

Compound 3, half-maximal inhibitory concentration: 1610 nM
Compound 3: the middle estimate sits 1.9-fold (0.27 log units) above what was measured; the range from low to high includes it.
By their numbers in this assay, from the lowest: compounds 1 and 3 (each within the scatter of the next); then compound 2.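

In this assay, chloro in place of bromo, on a carbon ortho to a fluoro group, gives a 2.3-fold lower number from compound 2 to compound 3 (0.35 log units; beyond the scatter) as a modest change, so this one halogen at this place can shift the number beyond the scatter. Replacing 4-bromophenyl with 3-chloro-4-fluorophenyl gives a 1.1-fold higher number from compound 1 to compound 3 (0.04 log units; within the scatter) within the scatter, which shows that a ring carrying a fluoro group does not by itself bring the higher number seen for compound 2. Nothing measured here accounts for the difference between bromo and chloro at this place.

On these data alone, whether the same swap would act alike on a ring without the fluoro group remains open. So does what a methyl group, a methoxy group or an amine would give at this same place on the ring.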